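Compound 3 to compound 4: amino in place of methyl

This account rests on a few compounds, and the source may have more. Where it says the series, first, only, none or still open, it means among the compounds named here.

In an ADME assay on the whole organism (strain Sprague-Dawley) with Rattus norvegicus as the target, read by LC-MS, at a dose of 50 mg/kg by the oral route (on this read-out higher numbers stand for a longer-lived compound and lower numbers for a shorter-lived compound), compound 1 `CCOC(=O)C1=C[C@@H](OC(CC)CC)[C@H](NC(C)=O)[C@@H](N/C(C)=N/O)C1` gives 3.43 h and compound 2 `CCOC(=O)C1=C[C@@H](OC(CC)CC)[C@H](NC(C)=O)[C@@H](N/C(N)=N\O)C1` gives 2.8 h. Compound 3 `CCOC(=O)C1=C[C@@H](OC(CC)CC)[C@H](NC(C)=O)[C@@H](NC(C)=N)C1` gives 1.62 h, the smallest number of the three. Among the compounds with values here, that position is firm in only one comparison: a 2.1-fold lower number from compound 1 to compound 3 (0.33 log units; beyond the scatter) lies just beyond the scatter, whereas a 1.7-fold lower number from compound 2 to compound 3 (0.24 log units; within the scatter) stays within it.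

Compound 4 `CCOC(=O)C1=C[C@@H](OC(CC)CC)[C@H](NC(C)=O)[C@@H](NC(=N)N)C1` differs from compound 3 by amino in place of methyl on a carbon with a double bond to nitrogen. Within the data shown here, the one measured step with the same exchange of methyl for amino is a 1.2-fold lower number from compound 1 to compound 2 (0.09 log units; within the scatter), and it is small and within the scatter. That pair is only a loose guide, since its group also holds an oxygen that compound 3 lacks, and a single pair shows no general trend. The other two steps replace that whole group and do not test this exchange. No step beyond the scatter is therefore expected in this assay, and no firm direction can be assigned. The expected step is a 1.1-fold lower number from compound 3 to compound 4 (0.03 log units; within the scatter), which would lie within the scatter. For compound 4 the estimate is 1.5 h, with an expected range of 0.8 h to 2.8 h.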

Compound 4, mean residence time: 2.62 h
Beside the measured number, compound 4's estimate is 1.7-fold (0.24 log units) below it; low and high end bracket the measured number.
By their numbers in this assay, from the lowest: compounds 3, 4, 2 and 1 (each within the scatter of the next, the first and the last beyond it).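

In this assay, amino in place of methyl on a carbon with a double bond to nitrogen now has a reading on a group without oxygen, a 1.6-fold higher number from compound 3 to compound 4 (0.21 log units; within the scatter), and together with a 1.2-fold lower number from compound 1 to compound 2 (0.09 log units; within the scatter) it gives two pairs for this exchange, neither beyond the scatter and neither setting a shared direction. Loss of the oxygen-bearing group does not by itself separate compound 4 from the other compounds, as a 1.1-fold lower number from compound 2 to compound 4 (0.03 log units; within the scatter) and a 1.3-fold lower number from compound 1 to compound 4 (0.12 log units; within the scatter) both stay within the scatter, so a 2.1-fold lower number from compound 1 to compound 3 (0.33 log units; beyond the scatter) remains the only step beyond it among the four compounds. No measurement available here accounts for these numbers.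

Still open, going by these compounds, is whether any other group on a carbon with a double bond to nitrogen, such as an ethyl, a longer chain or a phenyl ring, would give a step beyond the scatter from compound 3. Also open, on these data alone, is whether this read-out responds more clearly to a change elsewhere on the shared core, such as a carboxylic acid in place of the ethyl ester.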